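The source may hold more compounds than are shown below. What is called first, only, known or untested is meant among the compounds shown, and "the series" means these compounds.

Measured so far in an assay on isolated protein (strain Sprague-Dawley) for inhibition of Amine oxidase [flavin-containing] B (Rattus norvegicus), read by spectrophotometry, with a stated time of 5 min; on this read-out higher numbers stand for weaker inhibition and lower numbers for stronger inhibition:
compound 1 `CCOc1cc(=O)oc2cc(OCc3cccc(Cl)c3)ccc12` gives 115 nM;
compound 2 `CC(C)Oc1cc(=O)oc2cc(OCc3cccc(Cl)c3)ccc12` gives 24500 nM;
compound 3 `O=C(COc1cc(=O)oc2cc(OCc3cccc(Cl)c3)ccc12)N1CCCCC1` gives 38900 nM.

Among these three, compound 3 carries the highest number in this assay. Its gap to the nearest neighbour is small, a 1.6-fold higher number from compound 2 to compound 3 (0.20 log units; within the scatter), while its gap to the other is large, a 340-fold higher number from compound 1 to compound 3 (2.53 log units; beyond the scatter).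

Compound 4 `Nc1cc(=O)oc2cc(OCc3cccc(Cl)c3)ccc12` differs from compound 3 in one place: amino in place of ((piperidin-1-yl)carbonyl)methoxy on an aromatic carbon. Going by the values given here, two measured steps bear on this position. Both show that enlarging the group attached there raised the number strongly: a 210-fold higher number from compound 1 to compound 2 (2.33 log units; beyond the scatter) and a 340-fold higher number from compound 1 to compound 3 (2.53 log units; beyond the scatter). Compound 4 moves the other way, to a group of a single heavy atom, smaller than anything measured so far. A large fall in the number is therefore expected for the step of a 26-fold lower number from compound 3 to compound 4 (1.41 log units; beyond the scatter). Among the compounds with values here, no measured compound carries an amino group at this place, so the size of the fall is uncertain and the range is set wide. For compound 4 the estimate in this assay is 1500 nM, between 150 nM and 15000 nM.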

Compound 4, half-maximal inhibitory concentration: 47.9 nM
Estimate against measurement, compound 4: 31-fold (1.50 log units) above, outside the stated range (below it).
By their numbers in this assay, from the lowest: compound 4; then compound 1; then compounds 2 and 3 (each within the scatter of the next).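

In this assay, compound 4 gives the lowest number of the four, so strong inhibition at this place on the core does not need a chain attached through oxygen. The change from ethoxy to amino brings only a modest fall (a 2.4-fold lower number from compound 1 to compound 4 (0.38 log units; beyond the scatter)), whereas the changes from isopropoxy (a 510-fold lower number from compound 2 to compound 4 (2.71 log units; beyond the scatter)) and from ((piperidin-1-yl)carbonyl)methoxy (an 810-fold lower number from compound 3 to compound 4 (2.91 log units; beyond the scatter)) bring large ones, so amino extends the low end of the range only slightly while the two bulkier groups stay far above it. Nothing available explains why amino gives this result.

The compounds shown leave open whether methoxy, with its oxygen link, would match amino. They also leave open whether methylamino or dimethylamino would keep the number this low.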